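Fluoro to hydroxy swap on a chalcone-type series

The source may report more compounds than this note shows. Statements on the series, on what has been measured and on what is new or still open speak of the compounds shown alone.

Measured so far in a functional assay on K562 cells (Homo sapiens) for antiproliferative activity, read by MTT assay, with a stated time of 5 days; on this read-out lower numbers stand for stronger inhibition and higher numbers for weaker inhibition:
- compound 1 `COc1ccc(C(=Cc2ccc(OC)c(O)c2)C(=O)c2cc(OC)c(OC)c(OC)c2)cc1`: 12000 nM
- compound 2 `COc1ccc(C(=Cc2ccc(OC)c(F)c2)C(=O)c2cc(OC)c(OC)c(OC)c2)cc1`: 450000 nM
- compound 3 `COc1ccc(C=C(C(=O)c2cc(OC)c(OC)c(OC)c2)c2ccc(C)cc2)cc1F`: 570000 nM

Compound 1 and compound 2 share one core and differ only where (hydroxy in place of fluoro on an aromatic carbon), a change that made the step of a 38-fold lower number from compound 2 to compound 1 (1.57 log units; beyond the scatter). Compound 3 stands on a second core, which differs from that of compound 2 where (methyl in place of methoxy on an aromatic carbon), a change that gave the step of a 1.3-fold higher number from compound 2 to compound 3 (0.10 log units; within the scatter). Compound 4 `COc1ccc(C=C(C(=O)c2cc(OC)c(OC)c(OC)c2)c2ccc(C)cc2)cc1O`, not yet measured, carries the hydroxy on the core of compound 3, where (hydroxy in place of fluoro on an aromatic carbon); this is the same change as in the first pair. On that single precedent, the step from compound 3 to compound 4 is expected to be a 38-fold lower number from compound 3 to compound 4 (1.58 log units; beyond the scatter), with one earlier example only. Compound 4 is therefore estimated at 15000 nM in this assay, between 5000 nM and 60000 nM.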

Compound 4, half-maximal inhibitory concentration: 32000 nM
Beside the measured number, compound 4's estimate is 2.1-fold (0.33 log units) below it; the range from low to high includes it.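

In this assay, hydroxy in place of fluoro on the core of compound 3 gave an 18-fold lower number from compound 3 to compound 4 (1.25 log units; beyond the scatter), and the step carried over from the first core: the same change on two cores in this assay, a 38-fold lower number (1.57 log units; beyond the scatter) from compound 2 to compound 1 and an 18-fold lower number (1.25 log units; beyond the scatter) from compound 3 to compound 4, 2.1-fold (0.32 log units) apart, within the scatter of two such steps. Methyl in place of methoxy on the hydroxy pair gave a 2.7-fold higher number from compound 1 to compound 4 (0.43 log units; beyond the scatter), and this step does not differ from its counterpart on the fluoro pair: the same change on two cores in this assay, a 1.3-fold higher number (0.10 log units; within the scatter) from compound 2 to compound 3 and a 2.7-fold higher number (0.43 log units; beyond the scatter) from compound 1 to compound 4, 2.1-fold (0.32 log units) apart, within the scatter of two such steps. These two changes therefore add up consistently across the four compounds shown, but each comparison rests on only two steps in one cell assay, which does not establish a rule for the wider series and says nothing about why the numbers move.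

As far as these compounds go, whether an amine or a carboxylic acid at the place of the hydroxy would give a similar step remains open. So does whether an ethyl group or a longer chain in place of the methyl would keep the number close to that of the methoxy compounds.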